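Homologating the Amino Group of Compound 1

This account rests on a few compounds, and the source may have more. Where it says the series, first, only, none or still open, it means among the compounds named here.

Compound 1 `Cc1nc2c(OCc3ccccc3)cccn2c1N` is the reference of this pair. Within the data shown here, in a functional assay on the whole organism with Rattus norvegicus as the target, at a dose of 40 mg/kg by the intraperitoneal route (on this read-out higher numbers stand for more inhibition at the one dose given (going by the name of the read-out) and lower numbers for less inhibition), compound 1 gives 99%, the highest of the two numbers known. The other measured compound, compound 2 `CC(C)(C)c1nc2c(OCc3ccccc3)cccn2c1N`, gives 0% in this assay, and the step of a number 99 percentage points lower from compound 1 to compound 2 (beyond the scatter) comes with tert-butyl in place of methyl on an aromatic carbon. The unmeasured compound 3 `Cc1nc2c(OCc3ccccc3)cccn2c1CN` differs from compound 1 in another place: aminomethyl in place of amino on an aromatic carbon. No measured step touches the amino group itself, so the only shown step, at the methyl-bearing carbon, gives no direct guide; it shows only that the number in this assay is far lower after that one change. Compound 3 is therefore expected to lose part of the inhibition of compound 1, a step estimated as a number 54 percentage points lower from compound 1 to compound 3 (beyond the scatter), with wide uncertainty. In this assay compound 3 is estimated at 45%, within a range from 5% to 90%.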

Compound 3, a percentage reported as inhibition, in the whole organism at one dose (the size of the read-out at that dose, not a potency): 46%
The estimate for compound 3 lay 1 percentage points below the measured number; the measured number falls inside the stated range.
By their numbers in this assay, from the lowest: compound 2; then compound 3; then compound 1.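

Aminomethyl in place of amino comes with a number 53 percentage points lower from compound 1 to compound 3 (beyond the scatter) in this assay, so this position, which no earlier step touched, also bears on the number, yet inhibition is not lost, as compound 3 still gives 46%. The two groups have the same counts of hydrogen-bond donors and acceptors and no net charge, so a step of this size is seen here with no change in those counts, only with one added carbon. Nothing measured on these compounds explains the step.

The compounds shown leave open whether a longer chain such as aminoethyl would lower the number further, and what hydroxymethyl or dimethylamino would give at this position. They also do not tell whether the step would hold with another group in place of the methyl.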